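The compounds below may be only part of what the source reports. "The series", "measured", "known", "first", "only" and "open" are said of these compounds alone.

Measured so far:
compound 1 `COC(=O)CC1c2ccccc2N=C(Nc2ccc(-c3ccccc3)cc2)N1CCCCCN` — 1800 nM
compound 2 `CN(C)C1=Nc2ccccc2C(CC(=O)NCc2ccc([N+](=O)[O-])cc2)N1c1ccccc1` — 31600 nM
compound 3 `CCN1C(N2CCCCC2)=Nc2ccccc2C1CC(=O)NCc1ccc(NS(=O)(=O)c2ccc(F)cc2)cc1` — 17000 nM

In a functional assay on SK-MEL-2 cells (Homo sapiens) for inhibition, read by sulforhodamine B assay, with a stated time of 72 h (a lower number here means a stronger inhibitor of growth, a higher number a weaker inhibitor of growth), compound 2 gives 31600 nM, the highest of the three numbers. The nearest is compound 3 at 17000 nM, a gap within the scatter, so no order between the two can be read. The furthest is compound 1 at 1800 nM, a gap beyond the scatter.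

Compound 4 `CN(C)C1=Nc2ccccc2C(CC(=O)NCc2ccc(N)cc2)N1c1ccccc1` differs from compound 2 in one place: amino in place of nitro on an aromatic carbon. Going by the values given here, no pair of measured compounds differs by this change, so the size of the step in this assay has no precedent here; the expectation is for no step beyond the scatter, in either direction. Compound 4 is expected to give 25000 nM, in the range 8000 nM to 80000 nM. This estimate means a step of a 1.3-fold lower number from compound 2 to compound 4 (0.10 log units; within the scatter) that is expected to stay within the scatter.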

Compound 4, concentration for 50% growth inhibition: 44000 nM
Beside the measured number, compound 4's estimate is 1.8-fold (0.25 log units) below it; the range from low to high includes it.
By their numbers in this assay, from the lowest: compound 1; then compounds 3, 2 and 4 (each within the scatter of the next, the first and the last beyond it).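

In this assay, 4-nitrobenzyl to 4-aminobenzyl gives a 1.4-fold higher number from compound 2 to compound 4 (0.14 log units; within the scatter), so at this position the two groups cannot be told apart. The change removes a double bond outside aromatic rings and adds a hydrogen-bond donor, yet the step stays within the scatter. No available measurement bears on this result.

Going by these compounds, whether a carboxylic acid, a methoxy group or an acetamide at this position would give a step beyond the scatter remains open. On these data alone, whether amino in place of nitro behaves alike on another core also remains open.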